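Substitution on the core of a sulfonyl carbamoyl azaindole series

The source may report more compounds than this note shows. Statements on the series, on what has been measured and on what is new or still open speak of the compounds shown alone.

Measured compounds and their values:
Compound 1, `O=C(NS(=O)(=O)c1ccccc1)n1ccc2cccnc21`: 4500 nM
Compound 2, `O=C(NS(=O)(=O)c1ccc(Cl)cc1)n1ccc2cccnc21`: 10400 nM
Compound 3, `O=C(NS(=O)(=O)c1cccc([N+](=O)[O-])c1)n1ccc2cccnc21`: 800 nM

All three share one core, and each was tested in an assay on COS7 cells for inhibition of Ectonucleotide pyrophosphatase/phosphodiesterase family member 1 (Homo sapiens), with a stated time of 35 min; a higher number here means a weaker inhibitor, a lower number a stronger inhibitor. Among the three numbers, compound 1 stands second highest: compound 2 sits a 2.3-fold higher number from compound 1 to compound 2 (0.36 log units; beyond the scatter), while compound 3 sits a 5.6-fold lower number from compound 1 to compound 3 (0.75 log units; beyond the scatter), the largest gap on record here.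

Compound 4, `O=C(NS(=O)(=O)c1ccccc1)n1ccc2c(Cl)ccnc21`, is not yet measured. Against compound 1 the change is chloro in place of hydrogen on an aromatic carbon. The two known steps both alter the ring attached to the sulfonyl group, not the core: chloro there gave a 2.3-fold higher number from compound 1 to compound 2 (0.36 log units; beyond the scatter) and nitro there gave a 5.6-fold lower number from compound 1 to compound 3 (0.75 log units; beyond the scatter). Among the measured compounds shown here, no measured step touches the core ring at all, so neither of them bears directly on compound 4. What remains is that a chloro group on an aromatic carbon elsewhere produced only a modest shift; with nothing comparable on the core, the expectation is a step of no more than modest size in either direction, most likely within the scatter, a 1.1-fold higher number from compound 1 to compound 4 (0.05 log units; within the scatter). Compound 4 is therefore expected to give about 5000 nM, within the range 1500 nM to 16000 nM.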

Compound 4, half-maximal inhibitory concentration: 1080 nM
Compound 4: middle estimate off by 4.6-fold (0.67 log units), on the high side, outside the stated range (below it).
By their numbers in this assay, from the lowest: compounds 3 and 4 (each within the scatter of the next); then compound 1; then compound 2.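

The core is not a silent part of this series: chloro on an aromatic carbon of the six-membered aromatic ring with 1 nitrogen, opposite the ring nitrogen, gives a 4.2-fold lower number from compound 1 to compound 4 (0.62 log units; beyond the scatter) in this assay and so moves the number beyond the scatter. The same group in place of hydrogen on the ring attached to the sulfonyl group gave a 2.3-fold higher number from compound 1 to compound 2 (0.36 log units; beyond the scatter) instead, so with these two compounds the direction of the chloro step depends on where the chloro sits, and a result from one ring cannot be carried over to the other. No measurement given here explains why this core position and the sulfonyl ring respond in opposite directions.

The compounds shown leave open whether a fluoro group, a methoxy group or an amine on this same core carbon would also lower the number, which would show whether the gain is particular to chloro. They also leave open whether this core chloro and the nitro group of compound 3 would add up when placed together in one molecule.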